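The source may report more compounds than this note shows. Statements on the series, on what has been measured and on what is new or still open speak of the compounds shown alone.

Compound 1 `ClCc1ccccc1Cn1cnc2c(Cl)nc(Cl)nc21` gives 420 nM in a functional assay on HT-29 cells (Homo sapiens) for cytotoxicity, read by sulforhodamine B assay, with a stated time of 48 h; on this read-out higher numbers stand for weaker inhibition of growth and lower numbers for stronger inhibition of growth; compound 2 `ClCc1cccc(Cn2cnc3c(Cl)nc(Cl)nc32)c1` gives 2390 nM; compound 3 `Nc1nc(Cl)c2ncn(Cc3ccccc3CCl)c2n1` gives 3890 nM.

Compound 1 and compound 2 share the same atoms joined differently; the difference between the two cores is not broken down here. Compound 3 arises from compound 1 by one change, (amino in place of chloro on an aromatic carbon), and this brought a 9.3-fold higher number from compound 1 to compound 3 (0.97 log units; beyond the scatter). The unmeasured compound 4 `Nc1nc(Cl)c2ncn(Cc3cccc(CCl)c3)c2n1` arises from compound 2 by the same change, (amino in place of chloro on an aromatic carbon), at the same place. Among the compounds with values here, the step from compound 2 to compound 4 is therefore expected to be about a 7.5-fold higher number from compound 2 to compound 4 (0.88 log units; beyond the scatter) in this assay, resting on the one measured example, compound 1 to compound 3, with a 9.3-fold higher number from compound 1 to compound 3 (0.97 log units; beyond the scatter). On that basis compound 4 is estimated at 18000 nM, with a plausible range from 6000 nM to 50000 nM.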

Compound 4, concentration for 50% growth inhibition: 2510 nM
Compound 4: middle estimate off by 7.2-fold (0.86 log units), on the high side; measured number outside the range, below it.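

Putting amino in place of chloro on the core of the second pair gives a 1.1-fold higher number from compound 2 to compound 4 (0.02 log units; within the scatter) in this assay, so the two numbers of this pair cannot be told apart. The same change therefore does not carry a fixed size from one core to the other: the same change on two cores in this assay, a 9.3-fold higher number (0.97 log units; beyond the scatter) from compound 1 to compound 3 and a 1.1-fold higher number (0.02 log units; within the scatter) from compound 2 to compound 4, 8.8-fold (0.95 log units) apart, beyond the scatter of two such steps

Within the data shown here, with only two pairs, this does not show what sets the two steps apart, nor how the change would behave on any further core.

The compounds shown leave open how a methoxy group or a dimethylamino group would behave on the aromatic carbon between two ring nitrogen atoms. As far as these compounds go, it also stays open what a hydroxymethyl group would do in place of the chloromethyl group.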